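Ethoxy for iodo on the aryl ring of compound 2

This account rests on a few compounds, and the source may have more. Where it says the series, first, only, none or still open, it means among the compounds named here.

Of the compounds shown here, three sharing one core have been measured for an assay for binding affinity to adenosine receptor A1 (Bos taurus); a higher number here means a weaker inhibitor, a lower number a stronger inhibitor. Compound 2, `Cn1c(=O)c2nc(-c3ccc(I)cc3)[nH]c2n(C)c1=O`, gives 1.3 nM in this assay, the lowest of the three numbers. Compound 1, `CCn1c(=O)c2nc(-c3ccc(S(=O)(=O)N4CCSCC4)cc3)[nH]c2n(CC)c1=O`, gives 36.6 nM in this assay, and compound 3, `COc1cc(OC)cc(-c2nc3c(=O)n(C)c(=O)n(C)c3[nH]2)c1`, gives 500 nM in this assay; both of these stand beyond the scatter above compound 2, so compound 2 is the strongest inhibitor among the three.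

Compound 4, `CCOc1ccc(-c2nc3c(=O)n(C)c(=O)n(C)c3[nH]2)cc1`, has not yet been measured. It differs from compound 2 in one place: ethoxy in place of iodo on an aromatic carbon, an ethoxy in place of iodo on an aromatic carbon. Within the data shown here, no measured pair shows this exact step, so the size of the step can only be estimated from what the three numbers show. Since the two compounds that carry oxygen-bearing or larger groups on the aryl ring, compound 1 with 36.6 nM and compound 3 with 500 nM, sit well above compound 2, a move toward weaker inhibition is expected for compound 4, with an estimated step of a 15-fold higher number from compound 2 to compound 4 (1.19 log units; beyond the scatter) in this assay. Compound 4 is expected to give about 20 nM in this assay, within a range of 5 nM to 100 nM.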

Compound 4, half-maximal inhibitory concentration: 2 nM
Estimate against measurement, compound 4: 10-fold (1.00 log units) above; the measured number lies below the stated range.
By their numbers in this assay, from the lowest: compounds 2 and 4 (each within the scatter of the next); then compound 1; then compound 3.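

Within this assay the change of iodo to ethoxy, on an aromatic carbon para to a large group, gives a 1.5-fold higher number from compound 2 to compound 4 (0.19 log units; within the scatter). This is the first one-place comparison among these compounds, and it shows that this carbon can carry either a single iodine atom or an ethoxy group of 3 heavy atoms with 1 hydrogen-bond acceptor, with no change beyond the scatter. Nothing available accounts for why the two groups give matching numbers.

The compounds shown leave open how an amine, a carboxylic acid or a longer alkoxy chain at this carbon would read in this assay. They also leave open whether ethoxy and iodo would still match on the core of compound 1, which carries ethyl groups in place of the methyl groups.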